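This account rests on a few compounds, and the source may have more. Where it says the series, first, only, none or still open, it means among the compounds named here.

For the measured compounds named here, compound 2, `CCC[C@@H](CCO)Nc1nc(N)nc(C)c1Cc1ccc(CNC)cc1OC`, is the only compound of the set with a numeric result: in an assay on HEK293 cells for agonist activity at Toll-like receptor 8 (Homo sapiens) (a lower number here means that less compound is needed, a higher number that more compound is needed for the effect), compound 2 gives 6460 nM. Compound 1, `CCC[C@@H](CCO)Nc1nc(N)nc(C)c1Cc1ccc(CNC2CNC2)cc1OC`, carries an azetidin-3-yl instead of a methyl on the amine nitrogen. In this assay compound 1 reaches only a limit of the assay, > 10000 nM. That is the limit of > 10000 nM in this assay, at which 1 of the 2 values shown sits. The measured step between them is an at least 1.5-fold lower number from compound 1 to compound 2 (0.18 log units; that floor lies within the scatter). Compound 3, `CCC[C@@H](CCO)Nc1nc(N)nc(C)c1Cc1ccc(CNCCO)cc1OC`, is not yet measured; it differs from compound 2 by hydroxymethyl in place of hydrogen on a saturated chain carbon bound to an amine nitrogen. Going by the values given here, the one measured step touches the same amine nitrogen, yet it swaps a ring for a methyl and reads only as a floor, so it gives little guidance on going from methyl to 2-hydroxyethyl. The expected step is therefore small: a 1.1-fold higher number from compound 2 to compound 3 (0.03 log units; within the scatter) is expected to stay within the scatter. For compound 3 the estimate in this assay is 7000 nM, with a range from 2500 nM to 20000 nM.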

Compound 3, half-maximal effective concentration: > 10000 nM
Compound 3 gave a limit, no number; the forecaster's own chance of this, stated with the estimate: 30%; middle value at least 1.4-fold (0.15 log units) from the limit.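

The change from methyl to 2-hydroxyethyl on this amine nitrogen gives an at least 1.5-fold higher number from compound 2 to compound 3 (0.18 log units; that floor lies within the scatter) in this assay. So an open-chain group on this nitrogen, and not only the azetidin-3-yl ring of compound 1, can leave a compound at the limit of the assay, though neither floor shows a change beyond the scatter: the limit of > 10000 nM in this assay, at which 2 of the 3 values shown sit. The step between compound 1 and compound 3 cannot be read, so these two compounds cannot be ranked against each other.

The compounds shown do not separate the effect of the added hydroxyl from that of the added chain length, and an ethyl group on the same nitrogen would be needed to do so. They also leave open how a plain primary amine, with hydrogen in place of the methyl of compound 2, would read in this assay.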